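Chain extension in a carboxylesterase 1 inhibitor series

The source may report more compounds than this note shows. Statements on the series, on what has been measured and on what is new or still open speak of the compounds shown alone.

Measured so far:
Compound 1, `CCCCCCCCCCCCS(=O)(=O)CC(O)(O)C(F)(F)F`: in an assay on isolated protein for inhibition of liver carboxylesterase 1 (Homo sapiens), with a stated time of 5 min (on this read-out lower numbers stand for stronger inhibition and higher numbers for weaker inhibition), compound 1 gives 741 nM.
Compound 2, `CCCCCCCC[S+]([O-])CC(O)(O)C(F)(F)F`: in this assay compound 2 gives 14800 nM.
Compound 3, `CCCCCCCCCCS(=O)(=O)CC(O)(O)C(F)(F)F`: in this assay compound 3 gives 794 nM.

Compounds 3 and 1 differ in one place, (ethyl in place of hydrogen on a saturated chain carbon, ten or more bonds along the chain from a sulfonyl sulfur), and the step is a 1.1-fold lower number from compound 3 to compound 1 (0.03 log units; within the scatter). The two numbers are therefore to be read as one value; the chain extension leaves the read-out where it was.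

Compound 2 stands apart. Its number is the highest of the three, and the difference between its core and that of compound 3 is not broken down here. On the values alone, compound 3 gives 794 nM where compound 2 gives 14800 nM, a gap well beyond the scatter.

Compound 4, `CCCCCCCCCC[S+]([O-])CC(O)(O)C(F)(F)F`, is not yet measured. It is made from compound 2 by ethyl in place of hydrogen on a saturated chain carbon, eight bonds along the chain from a sulfur. Going by the values given here, this is the same kind of change as the one from compound 3 to compound 1, though the place along the chain and the sulfur it is counted from are not identical, as the two descriptions of the changes show. Among the compounds with values here, with only one such step on record, the expectation rests on it: because a 1.1-fold lower number from compound 3 to compound 1 (0.03 log units; within the scatter) lay within the scatter, the corresponding step is expected to be small as well, a 1.1-fold lower number from compound 2 to compound 4 (0.06 log units; within the scatter). Compound 4 is accordingly estimated at 13000 nM, with a likely range of 5000 nM to 35000 nM.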

Compound 4, inhibition constant: 5250 nM
The estimate for compound 4 lay 2.5-fold (0.39 log units) above the measured number; low and high end bracket the measured number.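

In this assay the replacement of hydrogen by ethyl, on a saturated chain carbon eight bonds along the chain from a sulfur, gives a 2.8-fold lower number from compound 2 to compound 4 (0.45 log units; beyond the scatter) and this step has to be read against the earlier one, from which it does not separate: the same change on two cores in this assay, a 1.1-fold lower number (0.03 log units; within the scatter) from compound 3 to compound 1 and a 2.8-fold lower number (0.45 log units; beyond the scatter) from compound 2 to compound 4, 2.6-fold (0.42 log units) apart, within the scatter of two such steps.

Going by these compounds alone, the two cores are therefore compatible with a single modest response to this change, even though only the step on the core of compound 2 lies beyond the scatter when taken alone. This does not show that the size of the step is identical on the two cores, nor that it differs, and two pairs, with the change at different places along the chain, are too few to set a general rule for carrying it to another core in this series.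

The compounds shown leave open how far the trend on the core of compound 4 continues with a longer chain, and whether a chain of the length of compound 1 on that core behaves like compound 4. They also leave open what a branched chain, or a phenyl ring or carboxylic acid at the far end of the chain, would do to the read-out on either core.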